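A smaller group on the amide-type nitrogen

A few compounds are considered here, and "the series" means these few. Any claim that something is new, unique, unknown or untested is made for them only; others in the source may bear on it.

In an ADME assay on microsomes from liver (Mus musculus, strain CD-1) for metabolic stability, read by LC-MS, tested at 2 uM (a higher number here means that the compound lasts longer, a lower number that the compound disappears faster), compound 1 `CC(=O)N1CCCC(NC(=O)c2ccncc2Nc2cc(-c3ccc4ccn(C)c4c3)c3nccnc3c2)C1` gives 0.4 h and compound 2 `CC(=O)N1CCOC(CNC(=O)c2ccncc2Nc2cc(-c3ccc4ccn(C)c4c3)c3nccnc3c2)C1` gives 0.217 h, so these two values lie within the scatter of each other. Compound 3 `CN1CC(NC(=O)c2ccncc2Nc2cc(-c3ccc4ccn(C)c4c3)c3nccnc3c2)C1` carries 1-methylazetidin-3-yl in place of (4-acetylmorpholin-2-yl)methyl on the amide-type nitrogen: 1-methylazetidin-3-yl in place of (4-acetylmorpholin-2-yl)methyl on an amide-type nitrogen. For the measured compounds named here, only one measured step bears on this change, at the same place: a 1.8-fold lower number from compound 1 to compound 2 (0.27 log units; within the scatter). With that single step as a guide, no change beyond the scatter is expected in this assay, and the estimated step is a 1.4-fold higher number from compound 2 to compound 3 (0.14 log units; within the scatter). The half-life of compound 3 is expected to be 0.3 h, with an estimated range of 0.12 h to 0.75 h.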

Compound 3, half-life in the Mus musculus assay: > 1 h
Compound 3 was reported as a limit; the forecaster's own chance of this, stated with the estimate: 5%; middle value at least 3.3-fold (0.52 log units) from the limit.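

In the Mus musculus assay compound 3 gives > 1 h, which is a limit and not a measured half-life: the limit of > 1 h in the Mus musculus assay, at which 1 of the 3 values shown sits.

In the Mus musculus assay, the change at this amide-type nitrogen now shows a clear effect, which the earlier pair, within the scatter, did not: 1-methylazetidin-3-yl gives an at least 4.6-fold higher number from compound 2 to compound 3 (0.66 log units; beyond the scatter) and an at least 2.5-fold higher number from compound 1 to compound 3 (0.39 log units; beyond the scatter). In a physicochemical assay for solubility, read by spectrophotometry, measured as kinetic solubility, at pH 8, tested at 500 uM (a higher number here means a more soluble compound, a lower number a less soluble compound), compound 2 gives 268 ug/mL and compound 3 gives 170 ug/mL, and the same change gives a 1.6-fold lower number from compound 2 to compound 3 (0.20 log units; within the scatter).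

Ring size, group size and the acetyl group all differ at once in compound 3, and which of these matters stays open. Also open, as far as these compounds go, is how 1-acetylazetidin-3-yl or an azetidine with a free ring amine would behave.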